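Swapping a dichlorophenyl for a dimethoxyphenyl on the carbonyl

A few compounds are considered here, and "the series" means these few. Any claim that something is new, unique, unknown or untested is made for them only; others in the source may bear on it.

Measured compounds:
Compound 1 `COc1cc(-c2cc(/C=C/C(=O)c3ccc(Cl)c(Cl)c3)[nH]n2)cc(OC)c1OC`: 96%
Compound 2 `COc1ccc(-c2cc(/C=C/C(=O)c3cc(OC)c(OC)c(OC)c3)[nH]n2)cc1OC`: 95%
Compound 3 `COc1ccc(-c2cc(/C=C/C(=O)c3ccc(N)cc3)[nH]n2)cc1`: 96%

In a functional assay on HCC 2998 cells (Homo sapiens) for cytotoxicity, read by sulforhodamine B assay, with a stated time of 48 h, tested at 0.01 uM (on this read-out lower numbers stand for a stronger effect and higher numbers for a weaker effect at the one concentration tested), compound 1 gives 96%, level with compound 3 and together the highest of the three numbers; its gap to compound 2 lies within the scatter, so none of the three stands apart. Compound 4 `COc1ccc(C(=O)/C=C/c2cc(-c3cc(OC)c(OC)c(OC)c3)n[nH]2)cc1OC` has not yet been measured. It differs from compound 1 in one place: 3,4-dimethoxyphenyl in place of 3,4-dichlorophenyl on a carbonyl carbon. Within the data shown here, no step between measured compounds is available, yet all three measured numbers sit close together at a weak effect, and compound 2 gives 95%. The step from compound 1 to compound 4 is therefore expected to be a number 1 percentage points lower from compound 1 to compound 4 (within the scatter), nothing beyond the scatter. Compound 4 is expected to give about 95%, between 86% and 102%.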

Compound 4, a percentage reported as activity, at one concentration (the size of the read-out at that concentration, not a potency): 93%
Beside the measured number, compound 4's estimate is 2 percentage points above it; the range from low to high includes it.
By their numbers in this assay, from the lowest: compounds 4, 2, 1 and 3 (each within the scatter of the next).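

In this assay, among these compounds, putting 3,4-dimethoxyphenyl in place of 3,4-dichlorophenyl on a carbonyl carbon gives a number 3 percentage points lower from compound 1 to compound 4 (within the scatter), the first comparison here of two compounds that differ in one place. At the one concentration tested, this exchange of aromatic groups therefore produces no change that stands out from the scatter. No measurement shown here helps explain this result. Still open, going by these compounds, is what a carboxylic acid or a longer chain would give on this carbonyl carbon. Also open, on these data alone, is whether this exchange would remain as small at another concentration.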